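Sulfur-linked cyclopentyl in a TRPV1 antagonist series

The source may report more compounds than this note shows. Statements on the series, on what has been measured and on what is new or still open speak of the compounds shown alone.

Three compounds sharing one core were compared in an assay on cells for antagonist activity at transient receptor potential cation channel subfamily V member 1 (Homo sapiens), read by FLIPR and calcium flux, with a stated time of 6 min; on this read-out lower numbers stand for stronger inhibition and higher numbers for weaker inhibition. Compound 1 `CCCCOc1nc(C(C)(C)C)ccc1CNC(=O)C(C)c1ccc(NS(C)(=O)=O)c(F)c1` gives 0.9 nM. Compound 2 `CC(C(=O)NCc1ccc(C(C)(C)C)nc1OC1CCCC1)c1ccc(NS(C)(=O)=O)c(F)c1` gives 1.5 nM, and the step of a 1.7-fold higher number from compound 1 to compound 2 (0.22 log units; within the scatter) is within the scatter. Compound 3 `CC(C(=O)NCc1ccc(C(C)(C)C)nc1SCCCN1CCCC1)c1ccc(NS(C)(=O)=O)c(F)c1` gives 17.1 nM, the highest number of the three; the steps of a 19-fold higher number from compound 1 to compound 3 (1.28 log units; beyond the scatter) and an 11-fold higher number from compound 2 to compound 3 (1.06 log units; beyond the scatter) are both large and beyond the scatter.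

Compound 4 `CC(C(=O)NCc1ccc(C(C)(C)C)nc1SC1CCCC1)c1ccc(NS(C)(=O)=O)c(F)c1` differs from compound 3 in one place: cyclopentyl in place of 3-(pyrrolidin-1-yl)propyl on a sulfur. The step from compound 2 to compound 3 bears on this change most directly, since it exchanged a cyclopentyloxy group for the (3-(pyrrolidin-1-yl)propyl)sulfanyl group and raised the number by an 11-fold higher number from compound 2 to compound 3 (1.06 log units; beyond the scatter). Among the measured compounds shown here, compound 4 carries cyclopentyl again, now on sulfur rather than oxygen, and no measured pair tells what that exchange of sulfur for oxygen does on its own. The return of the cyclopentyl group is therefore expected to lower the number for compound 4 by roughly a 5.7-fold lower number from compound 3 to compound 4 (0.76 log units; beyond the scatter) in this assay. Compound 4 is estimated at 3 nM, within a range of 1 nM to 10 nM.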

Compound 4, inhibition constant: 2.5 nM
Compound 4: middle estimate off by 1.2-fold (0.08 log units), on the high side; measured number inside the range.
By their numbers in this assay, from the lowest: compounds 1, 2 and 4 (each within the scatter of the next, the first and the last beyond it); then compound 3.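

In this assay, among the compounds shown here, cyclopentyl in place of 3-(pyrrolidin-1-yl)propyl on the sulfur gives a 6.8-fold lower number from compound 3 to compound 4 (0.84 log units; beyond the scatter) and so separates the side chain from the linking atom, which had changed together in the earlier steps to compound 3. With cyclopentyl held constant, the exchange of oxygen for sulfur gives a 1.7-fold higher number from compound 2 to compound 4 (0.22 log units; within the scatter) and stays within the scatter, so the large rise at compound 3 goes with its 3-(pyrrolidin-1-yl)propyl group and not with sulfur as such in this pair. The change from butoxy to cyclopentylsulfanyl gives a 2.8-fold higher number from compound 1 to compound 4 (0.44 log units; beyond the scatter) and is modest, and nothing shown here gives a reason for any of these steps.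

The compounds shown leave open whether the pyrrolidine ring or the propyl chain carrying it goes with the higher number. A plain butyl group on sulfur, or a cyclopentylamino group on the same aromatic carbon, would extend the comparison.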